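Working notes: methoxy to fluoro, compound 3 to compound 4

The compounds below may be only part of what the source reports. "The series", "measured", "known", "first", "only" and "open" are said of these compounds alone.

Values in an ADME assay on HEK293 cells (Homo sapiens) for cytotoxicity, read by MTT assay, with a stated time of 72 h (a lower number here means a stronger inhibitor, a higher number a weaker inhibitor), so far:
Compound 1 `COc1ccc(C(=O)N2CCN(CC(=O)N3CCN(CCCc4c[nH]c5ccccc45)CC3)CC2)cc1` gives 156000 nM
Compound 2 `O=C(CN1CCN(C(=O)c2ccc(Br)cc2)CC1)N1CCN(CCCc2c[nH]c3ccccc23)CC1` gives 71900 nM
Compound 3 `COc1ccc(C(=O)N2CCN(CC(=O)N3CCN(CCCc4c[nH]c5ccc(F)cc45)CC3)CC2)cc1` gives 141000 nM
Compound 4 `O=C(CN1CCN(C(=O)c2ccc(F)cc2)CC1)N1CCN(CCCc2c[nH]c3ccc(F)cc23)CC1` has no measurement yet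

Compound 3 lies within the scatter of both other measured compounds. Those two stand further apart, with a 2.2-fold lower number from compound 1 to compound 2 (0.34 log units; beyond the scatter) for bromo in place of methoxy on an aromatic carbon. Compound 4 differs from compound 3 as follows: fluoro in place of methoxy on an aromatic carbon and so carries fluoro in place of methoxy on an aromatic carbon, para to a large group.

Going by the values given here, the bromo step is the closest precedent, as it also removes the methoxy, but a different group enters there. The other measured step, a 1.1-fold lower number from compound 1 to compound 3 (0.04 log units; within the scatter) for fluoro in place of hydrogen on an aromatic carbon, involves a different change and says nothing direct about losing the methoxy. Among the compounds with values here, no measured step has fluoro replacing methoxy.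

A small shift toward a lower number is therefore expected, smaller than the bromo step and possibly lost in the scatter. The estimated step is a 1.4-fold lower number from compound 3 to compound 4 (0.15 log units; within the scatter) in this assay on this reasoning. The estimate for compound 4 is 100000 nM with 55000 nM to 170000 nM as the expected range.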

Compound 4, half-maximal inhibitory concentration: 102000 nM
Compound 4: middle estimate off by 1.0-fold (0.01 log units), on the low side; measured number inside the range.
By their numbers in this assay, from the lowest: compounds 2, 4, 3 and 1 (each within the scatter of the next, the first and the last beyond it).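

In this assay, the aromatic carbon para to a large group now has a second substituent change on record, and swapping the 4-methoxyphenyl for the 4-fluorophenyl on the core of compound 3 leaves the step inside the scatter (a 1.4-fold lower number from compound 3 to compound 4 (0.14 log units; within the scatter)). So the methoxy, with its oxygen and its hydrogen-bond acceptor, can leave this position without a change in the number that stands clear of the scatter, at least on the core that also carries the second fluoro. Going by these compounds alone, the only step at this position printed as beyond the scatter remains the bromo replacement on the core of compound 1 (a 2.2-fold lower number from compound 1 to compound 2 (0.34 log units; beyond the scatter)), and no measurement here explains why the fluoro and bromo steps read as they do.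

Going by these compounds, whether fluoro in place of methoxy reads the same on the core of compound 1, and whether bromo in place of methoxy holds on the core of compound 3, remains open. Also open, on these data alone, is whether an amine, a carboxylic acid or a longer chain on this aromatic carbon would produce a step beyond the scatter in this assay.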